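Methyl on the Phenyl Ring: Predicting Compound 4

The source may hold more compounds than are shown below. What is called first, only, known or untested is meant among the compounds shown, and "the series" means these compounds.

Compound 1 `NC(=O)c1ccc2[nH]c(-c3ccc4[nH]c(-c5ccccc5)nc4c3)nc2c1` carries a carbamoyl group and an unsubstituted phenyl ring. In a functional assay on RPMI 8402 cells (Homo sapiens) for cytotoxicity (on this read-out higher numbers stand for weaker inhibition and lower numbers for stronger inhibition), compound 1 reaches only the assay limit, > 25000 nM. Compound 2 `Cc1ccc(-c2nc3cc(-c4nc5cc(C(N)=O)ccc5[nH]4)ccc3[nH]2)cc1` differs by methyl in place of hydrogen on an aromatic carbon. In this assay compound 2 likewise gives only a limit, > 25000 nM. Hence a step that the two limits leave unreadable from compound 1 to compound 2, because both values sit at the limit of > 25000 nM in this assay, at which 2 of the 3 values shown sit. Compound 3 `CN1CCN(c2ccc3[nH]c(-c4ccc5[nH]c(-c6ccccc6)nc5c4)nc3c2)CC1` differs from compound 1 by 4-methylpiperazin-1-yl in place of carbamoyl on an aromatic carbon, and in this assay compound 3 gives 490 nM, which is an at least 51-fold lower number from compound 1 to compound 3 (1.70 log units; beyond the scatter). Compound 4 `Cc1ccccc1-c1nc2cc(-c3nc4cc(N5CCN(C)CC5)ccc4[nH]3)ccc2[nH]1` differs from compound 3 by methyl in place of hydrogen on an aromatic carbon, the same kind of change as between compound 1 and compound 2, though there the methyl stands para to a large group while here it stands ortho to a large group. That earlier step left no readable size, so the expectation rests on compound 3 and its value 490 nM. A modest step, a 1.4-fold higher number from compound 3 to compound 4 (0.15 log units; within the scatter), is expected. Compound 4 is therefore estimated at 700 nM, between 250 nM and 2500 nM.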

Compound 4, half-maximal inhibitory concentration: 590 nM
Beside the measured number, compound 4's estimate is 1.2-fold (0.07 log units) above it; the measured number falls inside the stated range.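

In this assay, methyl in place of hydrogen on the phenyl ring, ortho to a large group, gives a 1.2-fold higher number from compound 3 to compound 4 (0.08 log units; within the scatter) and so leaves the number within the scatter on the core of compound 3. The same change on the core of compound 1 offers no size to set against this, because the step from compound 1 to compound 2 cannot be read: the limit of > 25000 nM in this assay, at which 2 of the 4 values shown sit. One readable step therefore does not show that the change carries from one core to another, and in the unreadable pair the methyl also stands at a different place.

The compounds shown leave open whether methyl elsewhere on the phenyl ring of compound 3 would also stay within the scatter. They also leave open how a carboxylic acid or a longer amine chain would read in place of the 4-methylpiperazin-1-yl group.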